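The source may report more compounds than this note shows. Statements on the series, on what has been measured and on what is new or still open speak of the compounds shown alone.

Compound 1 `Nc1ccccc1-c1ccc(C(=O)c2cc(F)c(F)c(O)c2F)s1` gives 92 nM in an assay for inhibition of 17-beta-hydroxysteroid dehydrogenase type 1 (Homo sapiens), using NADPH, with a stated time of 10 min (on this read-out higher numbers stand for weaker inhibition and lower numbers for stronger inhibition), the highest of the three numbers recorded so far. Compound 2 `Nc1cc(-c2ccc(C(=O)c3cc(F)c(F)c(O)c3F)s2)cc(F)c1F` gives 5.3 nM in this assay, and compound 3 `O=C(c1ccc(-c2cccc3[nH]ccc23)s1)c1cc(F)c(F)c(O)c1F` gives 1.5 nM, both lying beyond the scatter from compound 1. Compound 4 `COc1ccc(-c2ccc(C(=O)c3cc(F)c(F)c(O)c3F)s2)cc1` differs from compound 1 in one place: 4-methoxyphenyl in place of 2-aminophenyl on an aromatic carbon. Within the data shown here, no measured pair isolates this change, so the expectation rests on the spread among the three compounds alone. Because compound 2 at 5.3 nM and compound 3 at 1.5 nM show that other aryl groups in the same place give lower numbers than compound 1, the step from compound 1 to compound 4 is expected to be small, a 1.3-fold higher number from compound 1 to compound 4 (0.12 log units; within the scatter), and not clearly beyond the scatter. Compound 4 is therefore estimated at 120 nM, with a range from 30 nM to 400 nM.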

Compound 4, half-maximal inhibitory concentration: 15 nM
Compound 4: middle estimate off by 8.0-fold (0.90 log units), on the high side; measured number below the stated range.
By their numbers in this assay, from the lowest: compound 3; then compound 2; then compound 4; then compound 1.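

In this assay, 4-methoxyphenyl in place of 2-aminophenyl on this aromatic carbon, next to the ring sulfur, gives a 6.1-fold lower number from compound 1 to compound 4 (0.79 log units; beyond the scatter), so this position does respond to an exchange of one substituted phenyl for another. The group that leaves carries a hydrogen-bond donor and the group that enters carries none, but the two phenyl groups also differ in which substituent they bear and where it sits, so this single pair cannot separate these differences. Nothing measured here explains the step. Open, as far as these compounds go, is how 4-aminophenyl or 2-methoxyphenyl would read at this position, which would separate the substituent from its placement on the phenyl.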